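The source may report more compounds than this note shows. Statements on the series, on what has been measured and on what is new or still open speak of the compounds shown alone.

In a functional assay on Bel-7402 cells (Homo sapiens) for cytotoxicity, read by MTT assay, with a stated time of 72 h (on this read-out lower numbers stand for stronger inhibition and higher numbers for weaker inhibition), compound 1 `C=C1C(=O)[C@@]23C(=O)OC[C@]4(C(=O)CCC(C)(C)[C@H]4C=O)[C@@H]2CC[C@@H]1[C@H]3O` gives 5030 nM and compound 2 `C=C1C(=O)[C@@]23C(=O)OC[C@]4(C(=O)CCC(C)(C)[C@H]4C=O)[C@@H]2CC[C@@H]1[C@H]3OC(=O)CC` gives 1650 nM. Putting propanoyl in place of hydrogen on the oxygen accounts for a 3.0-fold lower number from compound 1 to compound 2 (0.48 log units; beyond the scatter). Compound 3 `C=C1C(=O)[C@@]23C(=O)OC[C@]4(C(=O)CCC(C)(C)[C@H]4C=O)[C@@H]2CC[C@@H]1[C@H]3OC(=O)c1ccc([N+](=O)[O-])cc1`, at 3300 nM, sits within the scatter of both, with a 1.5-fold lower number from compound 1 to compound 3 (0.18 log units; within the scatter) and a 2.0-fold higher number from compound 2 to compound 3 (0.30 log units; within the scatter). Compound 4 `C=C1C(=O)[C@@]23C(=O)OC[C@]4(C(=O)CCC(C)(C)[C@H]4C=O)[C@@H]2CC[C@@H]1[C@H]3OC(=O)c1ccc(F)cc1` differs from it at one place: fluoro in place of nitro on an aromatic carbon, para to a large group. Within the data shown here, no measured step changes this group directly. The closest evidence, a 2.0-fold higher number from compound 2 to compound 3 (0.30 log units; within the scatter), stays within the scatter, so no step beyond the scatter is expected in this assay. The expected step is a 1.1-fold lower number from compound 3 to compound 4 (0.04 log units; within the scatter). For compound 4 the estimated value is 3000 nM, with an expected range of 1300 nM to 6500 nM.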

Compound 4, half-maximal inhibitory concentration: 3750 nM
Compound 4: the middle estimate sits 1.3-fold (0.10 log units) below what was measured; low and high end bracket the measured number.
By their numbers in this assay, from the lowest: compounds 2, 3, 4 and 1 (each within the scatter of the next, the first and the last beyond it).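

Fluoro in place of nitro on an aromatic carbon, para to a large group, gives a 1.1-fold higher number from compound 3 to compound 4 (0.06 log units; within the scatter) in this assay, so this swap leaves the number essentially unmoved. The (4-fluorophenyl)carbonyl group also stays close to the free hydrogen, with a 1.3-fold lower number from compound 1 to compound 4 (0.13 log units; within the scatter), while a 2.3-fold higher number from compound 2 to compound 4 (0.36 log units; beyond the scatter) now separates an aromatic acyl group from propanoyl by more than the scatter. Nothing at hand bears on why the numbers fall this way. Going by these compounds, whether an amine on that aromatic carbon, or a longer chain in place of propanoyl, would shift the number remains open.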